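Ortho substituent on the aryl ring: trifluoromethylcarbonyl to cyano

The source may report more compounds than this note shows. Statements on the series, on what has been measured and on what is new or still open speak of the compounds shown alone.

The series keeps the shared core of compound 1 `O=C(CCCCCCc1ccccc1)c1ncc(-c2ccccc2F)o1` and varies the group on the six-membered aromatic ring. In an assay (Rattus norvegicus) for inhibition of Fatty-acid amide hydrolase 1 (Homo sapiens) (on this read-out higher numbers stand for weaker inhibition and lower numbers for stronger inhibition), compound 1 gives 110 nM. Compound 2 `NS(=O)(=O)c1ccccc1-c1cnc(C(=O)CCCCCCc2ccccc2)o1` carries sulfamoyl there and in this assay compound 2 gives 1500 nM. Compound 3 `O=C(CCCCCCc1ccccc1)c1ncc(-c2ccccc2C(=O)C(F)(F)F)o1` carries the (trifluoromethyl)carbonyl and in this assay compound 3 gives 5000 nM, the highest of the three numbers; its nearest neighbour is compound 2 and its furthest is compound 1.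

Compound 4 `N#Cc1ccccc1-c1cnc(C(=O)CCCCCCc2ccccc2)o1` is the next member. The change from compound 3 is cyano in place of (trifluoromethyl)carbonyl on an aromatic carbon. The measured steps that bear on this position are a 14-fold higher number from compound 1 to compound 2 (1.13 log units; beyond the scatter), a 45-fold higher number from compound 1 to compound 3 (1.66 log units; beyond the scatter) and a 3.3-fold higher number from compound 2 to compound 3 (0.52 log units; beyond the scatter): moving from fluoro to either of the two groups with more heavy atoms raised the number, and the (trifluoromethyl)carbonyl sat highest. Cyano, with 2 heavy atoms, lies closer to fluoro in what is counted than to either of the other groups, so a step back toward compound 1 is expected, beyond the scatter and downward, though not necessarily all the way. The expected step is a 13-fold lower number from compound 3 to compound 4 (1.10 log units; beyond the scatter). For compound 4 the estimate in this assay is 400 nM, with a range from 100 nM to 1600 nM.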

Compound 4, inhibition constant: 130 nM
For compound 4 the middle estimate is 3.1-fold (0.49 log units) above the measured one; measured number inside the range.
By their numbers in this assay, from the lowest: compounds 1 and 4 (each within the scatter of the next); then compound 2; then compound 3.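

In this assay the rise away from fluoro is not general at this position: cyano gives a 38-fold lower number from compound 3 to compound 4 (1.59 log units; beyond the scatter) and a 12-fold lower number from compound 2 to compound 4 (1.06 log units; beyond the scatter) while remaining on the same aromatic carbon of the shared core. With a 1.2-fold higher number from compound 1 to compound 4 (0.07 log units; within the scatter) fluoro and cyano cannot be separated here, so compounds 1 and 4 form a low pair, apart from the higher numbers of compound 2 and compound 3, and the exchange of (trifluoromethyl)carbonyl for cyano shows that this large step can occur with hydrogen-bond donors and acceptors unchanged in count while heavy atoms fall from 6 to 2. No measurement among those shown gives a reason for these steps.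

From the compounds shown here alone, whether a low number at this position extends to other small groups stays open, as a hydrogen, a chlorine, a methyl, a methoxy, an amine or a carboxylic acid on the same carbon would test. Also open, going by these compounds, is whether cyano and fluoro remain indistinguishable when a shorter or longer chain replaces the chain of the shared core.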